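Swapping a pyridine for a fluorophenyl on the ring nitrogen

The source may hold more compounds than are shown below. What is called first, only, known or untested is meant among the compounds shown, and "the series" means these compounds.

Three compounds share one core and differ only in the aromatic group on an amine nitrogen in a ring. Compound 1 `Nc1scc(CN2CCN(c3ccc(Cl)cc3F)CC2)c1C(=O)c1ccc(Cl)cc1` and compound 2 `Nc1scc(CN2CCN(c3ccc(Cl)c(C(F)(F)F)c3)CC2)c1C(=O)c1ccc(Cl)cc1` carry halogenated phenyl groups there; compound 3 `Nc1scc(CN2CCN(c3cccnc3)CC2)c1C(=O)c1ccc(Cl)cc1` carries pyridin-3-yl. In a functional assay on CHO cells with adenosine receptor A1 (Homo sapiens) as the target, read by cAMP accumulation and immunoassay, with a stated time of 6 min, tested at 0.1 uM (a higher number here means a weaker effect of the compound at the concentration tested, a lower number a stronger effect), compound 1 gives -9.4% and compound 2 gives -12%, while compound 3 gives 3.4%, the highest of the three numbers, that is the weakest effect. The steps of a number 12.8 percentage points higher from compound 1 to compound 3 (beyond the scatter) and a number 15.4 percentage points higher from compound 2 to compound 3 (beyond the scatter) both lie beyond the scatter, whereas a number 2.6 percentage points lower from compound 1 to compound 2 (within the scatter) does not.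

Compound 4 `Nc1scc(CN2CCN(c3ccccc3F)CC2)c1C(=O)c1ccc(Cl)cc1` is the next step: 2-fluorophenyl in place of pyridin-3-yl on an amine nitrogen in a ring. This change runs opposite to the two steps that raised the number toward compound 3, since a carbon-only ring with a fluorine returns in place of the pyridine. Because of a number 12.8 percentage points higher from compound 1 to compound 3 (beyond the scatter) a drop of roughly that size is expected, giving a number 11.4 percentage points lower from compound 3 to compound 4 (beyond the scatter). Compound 4 is therefore estimated at -8%, with a likely range from -22% to 6%.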

Compound 4, a percentage reported as activity, at one concentration (the size of the read-out at that concentration, not a potency): -1%
Compound 4: middle estimate off by 7 percentage points, on the low side; the measured number falls inside the stated range.
By their numbers in this assay, from the lowest: compounds 2, 1, 4 and 3 (each within the scatter of the next, the first and the last beyond it).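

In this assay the step of a number 4.4 percentage points lower from compound 3 to compound 4 (within the scatter) shows that a carbon-only ring with a fluorine cannot be told apart from pyridin-3-yl at this position. Hydrogen in place of chloro on that fluorophenyl ring, the step of a number 8.4 percentage points higher from compound 1 to compound 4 (within the scatter), likewise gives no readable change, while only the step of a number 11 percentage points higher from compound 2 to compound 4 (beyond the scatter) clears the scatter, so the earlier split between halogenated phenyl groups and the pyridine does not hold as a simple divide between carbon-only rings and pyridine. Nothing available here explains these numbers.

As far as these compounds go, how a plain phenyl, a pyridin-4-yl or a methoxyphenyl group would read on this ring nitrogen remains open. So does whether these small differences at a single concentration would carry over to a full measure of potency.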